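Urea aryl exchange on the shared core: dichlorophenyl analogue

This account rests on a few compounds, and the source may have more. Where it says the series, first, only, none or still open, it means among the compounds named here.

Among the compounds with values here, compound 1 `COc1cc2cc(Oc3ccc(NC(=O)Nc4ccc(C)cc4)cc3)c(C)nc2cc1OC` stands at the top of the two numbers known so far, giving 102% in a functional assay on NCI-H226 cells (Homo sapiens) for inhibition, read by sulforhodamine B assay, with a stated time of 48 h, tested at 10 uM; a higher number here means a weaker effect of the compound at the concentration tested, a lower number a stronger effect. Within the data shown here, compound 2 `COc1cc2cc(Oc3ccc(NC(=O)Nc4ccc(C(F)(F)F)cc4)cc3)c(C)nc2cc1OC` gives 20.9% in this assay, and the step of a number 81.1 percentage points lower from compound 1 to compound 2 (beyond the scatter) is the only measured step. Compound 3 `COc1cc2cc(Oc3ccc(NC(=O)Nc4ccc(Cl)c(Cl)c4)cc3)c(C)nc2cc1OC` has not yet been tested; it differs from compound 1 by 3,4-dichlorophenyl in place of 4-methylphenyl on an amide-type nitrogen. Among the measured compounds shown here, the step from compound 1 to compound 2 bears on the present change, since in both cases the methyl on an aromatic carbon leaves and a halogen-bearing group enters, though no measured step covers the dichlorophenyl group itself. For the measured compounds named here, a large drop in this assay is therefore expected, a number 67 percentage points lower from compound 1 to compound 3 (beyond the scatter), with wide uncertainty because a number 81.1 percentage points lower from compound 1 to compound 2 (beyond the scatter) is the sole guide. Compound 3 is estimated at 35% in this assay, within 10% to 75%.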

Compound 3, a percentage reported as activity, at one concentration (the size of the read-out at that concentration, not a potency): 7.74%
For compound 3 the middle estimate is 27.3 percentage points above the measured one; measured number outside the range, below it.
By their numbers in this assay, from the lowest: compound 3; then compound 2; then compound 1.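

At the amide-type nitrogen, a second halogen-bearing aryl group also lowers the read-out in this assay, with a number 94.3 percentage points lower from compound 1 to compound 3 (beyond the scatter) for the exchange of 4-methylphenyl for 3,4-dichlorophenyl. The drop seen earlier is therefore not confined to 4-(trifluoromethyl)phenyl. The two halogen-bearing groups also separate from each other, with a number 13.2 percentage points lower from compound 2 to compound 3 (beyond the scatter) on going to 3,4-dichlorophenyl, and no supporting data bear on why either step occurs.

The aryl groups shown on this nitrogen carry only methyl, trifluoromethyl or chlorine, so it remains open how a phenyl ring with one chlorine, a methoxy group or a nitrile would read out, or a saturated cyclohexyl group. Also open, on these data alone, is whether the order of these three compounds would hold if an amide replaced the urea.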